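The source may report more compounds than this note shows. Statements on the series, on what has been measured and on what is new or still open speak of the compounds shown alone.

Compound 2 `CCN(CC)S(=O)(=O)c1ccc(S(=O)(=O)N2CCC[C@@H](C(=O)N3CCOCC3)C2)cc1` is tested in a functional assay on MIA PaCa-2 cells (Homo sapiens) for inhibition, read by MTT assay, with a stated time of 7 days (a higher number here means a weaker inhibitor, a lower number a stronger inhibitor), where compound 2 gives 350 nM. Among the three compounds measured so far it stands second highest: compound 1 `CCN(CC)S(=O)(=O)c1ccc(S(=O)(=O)N2CCC[C@@H](C(=O)N3CCS(=O)(=O)CC3)C2)cc1` gives 900 nM, while compound 3 `CC(C)S(=O)(=O)c1ccc(S(=O)(=O)N2CCC[C@@H](C(=O)N3CCC(F)(F)CC3)C2)cc1` gives 11 nM. Going by the values given here, the only step between measured compounds that differ in a single place is a 2.6-fold lower number from compound 1 to compound 2 (0.41 log units; beyond the scatter), a modest shift that comes from exchanging the ring that sits on the carbonyl carbon.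

Compound 4 `CCN(CC)S(=O)(=O)c1ccc(S(=O)(=O)N2CCC[C@@H](C(=O)N3CCC(C(F)F)CC3)C2)cc1` continues from compound 2 with one change: 4-(difluoromethyl)piperidin-1-yl in place of morpholin-4-yl on a carbonyl carbon. The step from compound 1 to compound 2 bears on this, as it is likewise a swap of the ring on the carbonyl carbon, and it moved the number modestly downward. Among the compounds with values here, compound 3 differs from compound 2 in two places, one of them also the ring on the carbonyl carbon, so no single step can be drawn from it; its values with compound 2 merely show that a much lower number is reachable. On that basis a downward step is expected, estimated as a 5.0-fold lower number from compound 2 to compound 4 (0.70 log units; beyond the scatter). Compound 4 is therefore estimated to give 70 nM, with a likely range from 15 nM to 300 nM.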

Compound 4, half-maximal inhibitory concentration: 420 nM
The estimate for compound 4 lay 6.0-fold (0.78 log units) below the measured number; measured number outside the range, above it.
By their numbers in this assay, from the lowest: compound 3; then compounds 2 and 4 (each within the scatter of the next); then compound 1.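

Replacing morpholin-4-yl with 4-(difluoromethyl)piperidin-1-yl on a carbonyl carbon gives a 1.2-fold higher number from compound 2 to compound 4 (0.08 log units; within the scatter) in this assay, so this assay does not tell the two groups apart, even though the new group has 9 heavy atoms against 6 and no hydrogen-bond acceptor against 1. Measured against the 1,1-dioxothiomorpholin-4-yl of compound 1, the new group gives a 2.1-fold lower number from compound 1 to compound 4 (0.33 log units; beyond the scatter), which runs the same way as a 2.6-fold lower number from compound 1 to compound 2 (0.41 log units; beyond the scatter), so among these three groups on the core of compound 1, only 1,1-dioxothiomorpholin-4-yl stands apart from the others. Nothing measured alongside these compounds speaks to why morpholin-4-yl and 4-(difluoromethyl)piperidin-1-yl read alike.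

Compound 3, at 11 nM, differs from each of the other compounds in two places, so its steps cannot be read, and the compounds shown do not settle how much of its low number belongs to the group on the carbonyl carbon. Also open, on these data alone, is how the number would respond on that same carbonyl carbon to a group without a ring, such as a dimethylamino group, or to a piperidine ring bearing a carboxylic acid.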